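Swapping the aryl group on a ring nitrogen

The compounds below may be only part of what the source reports. "The series", "measured", "known", "first", "only" and "open" are said of these compounds alone.

The compounds here share one core and were tested in a functional assay on MCF7 cells (Homo sapiens) for antiproliferative activity, read by MTT assay, with a stated time of 48 h; a lower number here means a stronger inhibitor, a higher number a weaker inhibitor. Compound 1 `N#CC1=C(N)Oc2c(c3nc4ccccc4nc3c3ccccc23)C12C(=O)N(Cc1cnnn1-c1ccc(N)cc1)c1ccccc12` is one of them. In this assay compound 1 gives only a limit, > 50000 nM. Compound 2 `Cc1ccccc1-n1nncc1CN1C(=O)C2(C(C#N)=C(N)Oc3c(N)cc4nc5ccccc5nc4c32)c2ccccc21` carries a 2-methylphenyl on an aromatic nitrogen of a five-membered aromatic ring with 3 nitrogen. In this assay compound 2 also gives only a limit, > 50000 nM. Where compound 2 stands is set by the limit of > 50000 nM in this assay, at which 2 of the 2 values shown sit: no number, only the edge of what the assay reports. Compound 3 `CCOc1ccc(-n2nncc2CN2C(=O)C3(C(C#N)=C(N)Oc4c(N)cc5nc6ccccc6nc5c43)c3ccccc32)cc1` is not yet measured. It differs from compound 2 as follows: 4-ethoxyphenyl in place of 2-methylphenyl on an aromatic nitrogen. Within the data shown here, since neither measured compound gives a number, no measured step can guide the size of this change. Compound 3 is expected to stay near the limit, with an estimated step of a number no higher from compound 2 to compound 3 (the limit leaves the size open). Compound 3 is estimated at 50000 nM, between 15000 nM and 100000 nM.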

Compound 3, half-maximal inhibitory concentration: 26800 nM
Beside the measured number, compound 3's estimate is 1.9-fold (0.27 log units) above it; low and high end bracket the measured number.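

Among these compounds, compound 3 is the first compound here to give a number rather than a limit in this assay, which shows that the group on this aromatic nitrogen can bring the series into the range the assay can read. Putting 4-ethoxyphenyl in place of 2-methylphenyl gives an at least 1.8-fold lower number from compound 2 to compound 3 (0.27 log units; that floor lies within the scatter). That floor is all that can be read, because compound 2 has no number of its own: the limit of > 50000 nM in this assay, at which 2 of the 3 values shown sit.

The change replaces one group with another that differs in its chain, its oxygen and its place on the six-membered ring, so the compounds shown cannot say which of these matters. A plain phenyl, a 4-methylphenyl or a 4-methoxyphenyl on the same nitrogen would begin to separate them.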